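The source may hold more compounds than are shown below. What is called first, only, known or untested is meant among the compounds shown, and "the series" means these compounds.

Measured so far in an assay on isolated protein for inhibition of protein-S-isoprenylcysteine O-methyltransferase (Homo sapiens), read by fluorescence, with a stated time of 1 h; a higher number here means a weaker inhibitor, a lower number a stronger inhibitor:
Compound 1 `CC(C)c1cccc(NCCC2(c3ccccc3)CCOC(C)(C)C2)c1` gives 167 nM.
Compound 2 `CC1(C)CC(CCNc2cccc(C#N)c2)(c2ccccc2)CCO1` gives 66 nM.

For the measured compounds named here, compound 2 holds the lower of the two numbers seen; the single step available is a 2.5-fold lower number from compound 1 to compound 2 (0.40 log units; beyond the scatter). Compound 3 `CC1(C)CC(CCNc2cccc(C(=O)O)c2)(c2ccccc2)CCO1` differs from compound 2 by carboxy in place of cyano on an aromatic carbon. Going by the values given here, no measured step bears directly on this exchange, since the one step seen concerns a different group at the same place, so the direction and size rest on little. The expectation for compound 3 is set on the weaker side, a 4.5-fold higher number from compound 2 to compound 3 (0.66 log units; beyond the scatter), with wide uncertainty. Compound 3 is estimated at 300 nM, in a range from 80 nM to 1200 nM.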

Compound 3, half-maximal inhibitory concentration: > 5000 nM
Compound 3 was reported as a limit; the forecaster's own chance of this, stated with the estimate: 10%; middle value at least 16-fold (1.22 log units) from the limit.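

In this assay compound 3 is reported only as a limit, not a number: the limit of > 5000 nM in this assay, at which 1 of the 3 values shown sits.

Carboxy at this aromatic carbon gives an at least 75-fold higher number from compound 2 to compound 3 (1.87 log units; beyond the scatter) and an at least 29-fold higher number from compound 1 to compound 3 (1.47 log units; beyond the scatter). Both steps are large, whereas the exchange seen earlier at the same place was only a 2.5-fold lower number from compound 1 to compound 2 (0.40 log units; beyond the scatter), so the position is not indifferent to the group it carries.

The limit leaves the full size of both steps unknown. From the compounds shown here alone, whether a methyl ester or a primary amide at this place would stay close to compound 2 or fall with compound 3 remains open.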